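Methoxy on the phenyl ring of a thiophene series

This account rests on a few compounds, and the source may have more. Where it says the series, first, only, none or still open, it means among the compounds named here.

Measured compounds:
Compound 1 `CC(C)(C)Cc1c(-c2ccccc2)sc(N)c1C(=O)c1cccc(Cl)c1`: 2%
Compound 2 `CC(C)(C)Cc1c(-c2ccccc2)sc(N)c1C(=O)c1ccc(Cl)cc1Cl`: 1%
Compound 3 `CC(C)(C)Cc1c(-c2ccccc2)sc(N)c1C(=O)c1cccc(C(F)(F)F)c1`: 1%

In an assay on CHO cells for displacement of a labelled ligand from adenosine receptor A1 (Homo sapiens), read by scintillation counting, tested at 10 uM (a lower number here means less inhibition, a higher number more inhibition at the concentration tested (going by the name of the read-out)), compound 3 stands level with compound 2 at the digits shown, the two together lowest of the three, and compound 1 is a single point higher, within the scatter. Both measured steps, a number 1 percentage points lower from compound 1 to compound 2 (within the scatter) and a number 1 percentage points lower from compound 1 to compound 3 (within the scatter), lie within the scatter. Compound 4 `COc1ccc(-c2sc(N)c(C(=O)c3cccc(C(F)(F)F)c3)c2CC(C)(C)C)cc1` differs from compound 3 by methoxy in place of hydrogen on an aromatic carbon on the phenyl ring attached to the shared core. Among the measured compounds shown here, no measured step touches that ring, so nothing directly bears on this change; all three numbers sit near the floor. The expected step is therefore a number 1 percentage points higher from compound 3 to compound 4 (within the scatter), none beyond the scatter. Compound 4 is estimated at 2%, between -8% and 12%.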

Compound 4, a percentage reported as inhibition, at one concentration (the size of the read-out at that concentration, not a potency): 2%
For compound 4 middle estimate and measured number coincide at the digits printed; the range from low to high includes it.
By their numbers in this assay, from the lowest: compounds 2, 3, 1 and 4 (each within the scatter of the next).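

Among the compounds shown here, the change from phenyl to 4-methoxyphenyl is the first measured change on this ring, and in this assay it gives a number 1 percentage points higher from compound 3 to compound 4 (within the scatter). Methoxy here therefore stays within the scatter, as did the earlier changes on the aromatic group on the carbonyl, and the number remains close to the floor of the assay. No supporting measurement gives a reason for this result. From the compounds shown here alone, whether an amine or a carboxylic acid at this same place would raise the number remains open. So does the effect of a longer chain in place of methoxy.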